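The source may report more compounds than this note shows. Statements on the series, on what has been measured and on what is new or still open speak of the compounds shown alone.

Measured so far:
compound 1 `CCN(C(C)=O)C(C)c1ccccc1N1CCN(C(=O)[C@H](CC(=O)N2CCC2)Cc2ccc(Cl)cc2)CC1` — 19 nM
compound 2 `CCN(C(C)=O)C(C)c1ccccc1N1CCN(C(=O)[C@H](CC(=O)NCc2ccccc2F)Cc2ccc(Cl)cc2)CC1` — 13 nM

Both compounds share the same core and differ only at the amide attached to the carbonyl carbon of the side chain. In an assay on isolated protein for binding affinity to Melanocortin receptor 4 (Homo sapiens) (a higher number here means a weaker inhibitor, a lower number a stronger inhibitor), compound 1 gives 19 nM and compound 2 gives 13 nM; the step of a 1.5-fold lower number from compound 1 to compound 2 (0.16 log units; within the scatter) lies within the scatter, so the two numbers cannot be ordered. Compound 2 has the lowest of the two numbers, but only by that margin.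

Compound 3 `CCN(C(C)=O)C(C)c1ccccc1N1CCN(C(=O)[C@H](CC(=O)NCc2ccccn2)Cc2ccc(Cl)cc2)CC1` has not been measured. It differs from compound 2 in one place: pyridin-2-yl in place of 2-fluorophenyl on a saturated chain carbon bound to an amide-type nitrogen. Going by the values given here, no measured step touches this ring; the only step on record, a 1.5-fold lower number from compound 1 to compound 2 (0.16 log units; within the scatter), concerns the exchange of the whole amine and is within the scatter, so the series so far suggests that changes at this end of the molecule are tolerated without large shifts. On that basis, compound 3 is expected to stay close to compound 2, with a step of a 1.4-fold higher number from compound 2 to compound 3 (0.14 log units; within the scatter), not beyond the scatter. The estimate for compound 3 in this assay is 18 nM, with a range from 7 nM to 50 nM.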

Compound 3, half-maximal inhibitory concentration: 32 nM
Estimate against measurement, compound 3: 1.8-fold (0.25 log units) below, within the range that was stated.
By their numbers in this assay, from the lowest: compounds 2, 1 and 3 (each within the scatter of the next, the first and the last beyond it).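

Pyridin-2-yl in place of 2-fluorophenyl, on a saturated chain carbon bound to an amide-type nitrogen, gives the first step in this series to lie beyond the scatter in this assay: a 2.5-fold higher number from compound 2 to compound 3 (0.39 log units; beyond the scatter) is modest in size but shows that this end of the molecule is not fully indifferent to the ring it carries, which compound 1 and compound 2 could not show. Against azetidin-1-yl on the carbonyl carbon, however, ((pyridin-2-yl)methyl)amino gives a 1.7-fold higher number from compound 1 to compound 3 (0.23 log units; within the scatter) and so cannot be ordered, which means the sensitivity seen here rests on one pair and does not extend to the amine exchange as a whole. Nothing at hand bears on what lies behind the shift between the two rings.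

Going by these compounds, the change removes the fluorine and brings in a ring nitrogen in one exchange, so the part played by each stays open. Plain phenyl on the same chain carbon would separate the two, while pyridin-3-yl and pyridin-4-yl would test whether the place of the ring nitrogen matters.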